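Pyrrolidine acetic acid series: aryl ether variations

This account rests on a few compounds, and the source may have more. Where it says the series, first, only, none or still open, it means among the compounds named here.

Measured so far in an assay on HEK293 cells for binding affinity to Free fatty acid receptor 1 (Homo sapiens), read by scintillation counting and radioligand binding, with a stated time of 1 h; a lower number here means a stronger inhibitor, a higher number a weaker inhibitor:
compound 1 `Cc1ccccc1Oc1ccc(N2C[C@@H](C(F)(F)F)C[C@H]2CC(=O)O)cc1`, 35 nM
compound 2 `Cc1ccccc1Cc1ccc(N2C[C@@H](C(F)(F)F)C[C@H]2CC(=O)O)cc1`, 73 nM
compound 3 `Cc1cccc(Oc2ccc(N3C[C@@H](C(F)(F)F)C[C@H]3CC(=O)O)cc2)c1C`, 60 nM

Compound 3 sits between the other two in this assay, and its steps to both are within the scatter: a 1.7-fold higher number from compound 1 to compound 3 (0.23 log units; within the scatter) and a 1.2-fold lower number from compound 2 to compound 3 (0.09 log units; within the scatter). Within the data shown here, the only step beyond the scatter is a 2.1-fold higher number from compound 1 to compound 2 (0.32 log units; beyond the scatter), which concerns the linker, not the substituent pattern on the outer ring.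

Compound 4 `Cc1c(Cl)cccc1Oc1ccc(N2C[C@@H](C(F)(F)F)C[C@H]2CC(=O)O)cc1` is not yet measured. It differs from compound 3 by chloro in place of methyl on an aromatic carbon. Among the measured compounds shown here, no measured step swaps chloro for methyl at this position. The nearest information is the step from compound 1 to compound 3, where adding methyl at this same position moved the number only within the scatter. On that basis the expectation for compound 4 is a change that stays within the scatter in this assay, with no clear direction, expressed as a 1.1-fold lower number from compound 3 to compound 4 (0.04 log units; within the scatter). The estimated value for compound 4 in this assay is 55 nM, with an expected range from 25 nM to 120 nM.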

Compound 4, inhibition constant: 13 nM
Estimate against measurement, compound 4: 4.2-fold (0.63 log units) above; the whole stated range lies above it.
By their numbers in this assay, from the lowest: compound 4; then compounds 1, 3 and 2 (each within the scatter of the next, the first and the last beyond it).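

In this assay this aromatic carbon, ortho to a methyl group, responds strongly to the identity of its substituent: chloro in place of methyl gives a 4.6-fold lower number from compound 3 to compound 4 (0.66 log units; beyond the scatter) and so separates two groups of one heavy atom each, whereas methyl in place of hydrogen had stayed within the scatter. Chloro in place of hydrogen gives a 2.7-fold lower number from compound 1 to compound 4 (0.43 log units; beyond the scatter) in the same assay, so the change also clears the unsubstituted outer ring. Against the benzyl compound, 3-chloro-2-methylphenoxy in place of 2-methylbenzyl gives a 5.6-fold lower number from compound 2 to compound 4 (0.75 log units; beyond the scatter) and leaves compound 4 as the strongest of the four.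

No available data explain why chloro and methyl differ here.

Open, as far as these compounds go, is whether fluoro, bromo or a nitrile at this carbon would follow chloro, and whether the gain persists without the 2-methyl group.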